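A few compounds are considered here, and "the series" means these few. Any claim that something is new, unique, unknown or untested is made for them only; others in the source may bear on it.

Compound 1 `COc1ccc(/C=C/c2cc(OC)cc(OC)c2/C=C/C(=O)c2ccc(N)cc2)cc1` gives 2.8 ug/mL in a functional assay on B16-F10 cells (Mus musculus) for antiproliferative activity, read by MTT assay, with a stated time of 48 h; on this read-out lower numbers stand for stronger inhibition and higher numbers for weaker inhibition; compound 2 `COc1ccc(/C=C/c2cc(OC)cc(OC)c2/C=C/C(=O)c2ccccc2C)cc1` gives 6.1 ug/mL.

Compound 2 thus holds the highest of the two numbers. Compound 3 `CCN(CC)c1ccc(C(=O)/C=C/c2c(/C=C/c3ccc(OC)cc3)cc(OC)cc2OC)cc1` differs from compound 2 in one place: 4-(diethylamino)phenyl in place of 2-methylphenyl on a carbonyl carbon. For the measured compounds named here, the only measured step that bears on this, a 2.2-fold higher number from compound 1 to compound 2 (0.34 log units; beyond the scatter), shows that exchanging 4-aminophenyl for 2-methylphenyl raised the number modestly. As compound 3 again carries a group of that first kind, 4-(diethylamino)phenyl, the reverse is expected, a step of a 1.7-fold lower number from compound 2 to compound 3 (0.24 log units; within the scatter) back toward the region of compound 1. Compound 3 is therefore estimated at 3.5 ug/mL, with a range from 1.5 ug/mL to 8 ug/mL.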

Compound 3, half-maximal inhibitory concentration: 8.1 ug/mL
The estimate for compound 3 lay 2.3-fold (0.36 log units) below the measured number; the whole stated range lies below it.
By their numbers in this assay, from the lowest: compound 1; then compounds 2 and 3 (each within the scatter of the next).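

On a carbonyl carbon, 4-(diethylamino)phenyl cannot be told apart from 2-methylphenyl, with a 1.3-fold higher number from compound 2 to compound 3 (0.12 log units; within the scatter). The amino and diethylamino groups do separate, since diethylamino in place of amino on an aromatic carbon gives a 2.9-fold higher number from compound 1 to compound 3 (0.46 log units; beyond the scatter), so the lower number of compound 1 does not carry over to every nitrogen-bearing group of this kind.

From the compounds shown here alone, whether methylamino or dimethylamino on that aromatic carbon would side with compound 1 or with compound 3 stays open. No evidence at hand explains either step.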